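The source may hold more compounds than are shown below. What is called first, only, known or untested is meant among the compounds shown, and "the series" means these compounds.

Among the measured compounds shown here, in a functional assay, read by spectrophotometry, with a stated time of 1 h (on this read-out higher numbers stand for weaker inhibition and lower numbers for stronger inhibition), compound 2, whose structure is `O=c1cc(/C=N\Nc2ccccc2)c2ccc(OCc3ccccc3)cc2o1`, gives 455000 nM, which is the highest of the three numbers measured so far. Its nearest neighbour is compound 3 `O=c1cc(/C=N\Nc2ccccc2)c2c(OCc3ccccc3)cc(OCc3ccccc3)cc2o1`, which gives 401000 nM; the step of a 1.1-fold lower number from compound 2 to compound 3 (0.05 log units; within the scatter) is within the scatter. Furthest away is compound 1 `O=c1cc(/C=N\c2ccc(O)cc2)c2ccc(OCc3ccccc3)cc2o1`, which gives 233000 nM; the step of a 2.0-fold higher number from compound 1 to compound 2 (0.29 log units; within the scatter) is also within the scatter.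

The compound not yet measured is compound 4 `O=c1cc(/C=N\c2ccccc2O)c2ccc(OCc3ccccc3)cc2o1`. It differs from compound 2 in one place: 2-hydroxyphenyl in place of anilino on a double-bonded nitrogen. For the measured compounds named here, the only measured step that touches this place is a 2.0-fold higher number from compound 1 to compound 2 (0.29 log units; within the scatter), where a hydroxyphenyl group stood on the same nitrogen instead of anilino and the number did not move beyond the scatter. The step of a 1.1-fold lower number from compound 2 to compound 3 (0.05 log units; within the scatter), a change at another place, was likewise within the scatter. Nothing among the three measured compounds points to a change beyond the scatter, so compound 4 is expected to give a number close to compound 2, perhaps leaning slightly toward compound 1 because of a 2.0-fold higher number from compound 1 to compound 2 (0.29 log units; within the scatter).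

Compound 4 is therefore estimated to give 280000 nM in this assay, with a range from 120000 nM to 650000 nM, an expected step of a 1.6-fold lower number from compound 2 to compound 4 (0.21 log units; within the scatter).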

Compound 4, half-maximal inhibitory concentration: "not active" (no number reported)
Compound 4 has no reported number here, and the estimate cannot be compared.
By their numbers in this assay, from the lowest: compounds 1, 3 and 2 (each within the scatter of the next).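

In this assay, among the compounds shown here, compound 4 is reported only as "not active", without a number, and no step linking it to compound 2 can be read. As far as these compounds go, how far 2-hydroxyphenyl in place of anilino moves the number stays open, as does where compound 4 stands among the others. Nothing shown here bears on this result.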